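The source may hold more compounds than are shown below. What is called first, only, known or untested is meant among the compounds shown, and "the series" means these compounds.

Series notes. Compound 1 `C[C@H](c1ccc(C(=O)NCCC(=O)O)cc1)N1C(=O)C(c2ccc(F)cc2)=N[C@]12CC[C@@H](C(C)(C)C)CC2` and compound 2 `CC(C)(C)[C@H]1CC[C@]2(CC1)N=C(c1ccc(C(F)(F)F)cc1)C(=O)N2Cc1ccc(C(=O)NCCC(=O)O)cc1` share a core and differ in how the aryl-bearing side is built out. In a functional assay on CHO cells for antagonist activity at Glucagon receptor (Homo sapiens), read by cAMP accumulation, with stated times of 30 min and 45 min (a lower number here means a stronger inhibitor, a higher number a weaker inhibitor), compound 1 gives 430 nM. In this assay compound 2 gives 800 nM. Compound 1 carries the lower of the two numbers, but the gap to compound 2 is within the scatter, so the two cannot be ordered on these data. Among the compounds with values here, no step between two measured compounds that differ in one place is available, so nothing measured tells how the aryl group alone moves the read-out.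

Compound 3 `C[C@H](c1ccc(C(=O)NCCC(=O)O)cc1)N1C(=O)C(c2cccc(OC(F)(F)F)c2)=N[C@]12CC[C@@H](C(C)(C)C)CC2` is not yet measured. It departs from compound 1 by 3-(trifluoromethoxy)phenyl in place of 4-fluorophenyl on a carbon with a double bond to nitrogen. Within the data shown here, with no measured step on this position, the expected change is modest: the step of a 1.4-fold lower number from compound 1 to compound 3 (0.16 log units; within the scatter) is estimated to fall at or only slightly beyond the scatter, on the stronger side. Compound 3 is therefore expected to give about 300 nM in this assay, within a range of 90 nM to 1000 nM.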

Compound 3, half-maximal inhibitory concentration: 840 nM
Compound 3: the middle estimate sits 2.8-fold (0.45 log units) below what was measured; measured number inside the range.
By their numbers in this assay, from the lowest: compounds 1, 2 and 3 (each within the scatter of the next).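

Within the data shown here, the first one-place step at this position, on a carbon with a double bond to nitrogen, reads in this assay as a 2.0-fold higher number from compound 1 to compound 3 (0.29 log units; within the scatter), so replacing 4-fluorophenyl with 3-(trifluoromethoxy)phenyl does not separate compound 1 from compound 3 beyond the usual scatter. The position therefore tolerates this larger aryl group without a change that can be resolved here, although the swap alters both the substituent and its place on the phenyl ring, and this single step cannot tell those two changes apart. No measurement shown here offers an explanation for the size of this step.

Still open, on these data alone, is whether an unsubstituted phenyl, a 4-(trifluoromethoxy)phenyl or a phenyl carrying an amine at this carbon would move the read-out beyond the scatter, which would show how far the position responds to the substituent and to its placement. Also open, as far as these compounds go, is whether the same aryl change behaves alike on the core of compound 2, and whether replacing the tert-butyl group with a longer alkyl chain would alter the read-out.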